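Isopropyl on the Ring Amide Nitrogen: Forecast for Compound 3

The source may hold more compounds than are shown below. What is called first, only, known or untested is meant among the compounds shown, and "the series" means these compounds.

Within the data shown here, compound 1 `COc1ncc(-c2ccc3c(c2)NC(=O)CO3)cc1NS(=O)(=O)c1ccc(F)cc1` is the only compound with a number here: in a functional assay on HepG2 cells (Homo sapiens) for antiproliferative activity, read by MTT assay, with a stated time of 72 h (on this read-out lower numbers stand for stronger inhibition and higher numbers for weaker inhibition), compound 1 gives 6590 nM. Compound 2 `O=C1COc2ccc(-c3cnc(Cl)c(NS(=O)(=O)c4ccc(F)cc4)c3)cc2N1` reaches only a limit of the assay, > 40000 nM. Among the measured compounds shown here, the single measured step, an at least 6.0-fold higher number from compound 1 to compound 2 (0.78 log units; beyond the scatter), concerns a different position. That step ends at the limit of > 40000 nM in this assay, at which 1 of the 2 values shown sits. Compound 3 `COc1ncc(-c2ccc3c(c2)N(C(C)C)C(=O)CO3)cc1NS(=O)(=O)c1ccc(F)cc1` differs from compound 1 by isopropyl in place of hydrogen on an amide-type nitrogen in a ring. For the measured compounds named here, no measured step touches that amide-type nitrogen, so the expected change a 1.2-fold higher number from compound 1 to compound 3 (0.08 log units; within the scatter) is small or none beyond the scatter. Compound 3 is therefore estimated at 8000 nM, expected between 2500 nM and 30000 nM.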

Compound 3, half-maximal inhibitory concentration: 37200 nM
Compound 3: middle estimate off by 4.7-fold (0.67 log units), on the low side; measured number above the stated range.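

The ring amide nitrogen, which the earlier step did not touch, proves sensitive in this assay: isopropyl in place of hydrogen gives a 5.6-fold higher number from compound 1 to compound 3 (0.75 log units; beyond the scatter). Compound 1 therefore responds to change at this nitrogen as well as at the aromatic carbon carrying the methoxy group, and here the weakening is a measured number. Compound 2 remains the only compound at a limit of the assay: the limit of > 40000 nM in this assay, at which 1 of the 3 values shown sits.

The compounds shown leave open whether a methyl or ethyl on this nitrogen would weaken activity as much as isopropyl. They also leave open how a chain ending in an amine or a carboxylic acid would read there.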